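The source may report more compounds than this note shows. Statements on the series, on what has been measured and on what is new or still open speak of the compounds shown alone.

Compound 1, `CN(C)CCn1c(N)c(-c2nc3ccccc3[nH]2)c2nc(C#N)c(C#N)nc21`, is recorded in a functional assay on A549 cells (Homo sapiens) for antiproliferative activity, read by MTT assay, with a stated time of 48 h (a lower number here means a stronger inhibitor, a higher number a weaker inhibitor), only as a limit of the assay: compound 1 gives > 50000 nM. Compound 2, `CCCn1c(N)c(-c2nc3ccccc3[nH]2)c2nc(C#N)c(C#N)nc21`, gives 1970 nM in this assay.

Going by the values given here, compound 2 therefore holds the only actual number in this assay; the single other value, that of compound 1, is a limit of the assay (the limit of > 50000 nM in this assay, at which 1 of the 2 values shown sits). Among the compounds with values here, the one measured step, an at least 25-fold lower number from compound 1 to compound 2 (1.40 log units; beyond the scatter), replaces a dimethylamino group on a saturated chain carbon, two bonds along the chain from an aromatic nitrogen, with methyl.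

Compound 3, `CCCCn1c(N)c(-c2nc3ccccc3[nH]2)c2nc(C#N)c(C#N)nc21`, differs from compound 2 by methyl in place of hydrogen on a saturated chain carbon, three bonds along the chain from an aromatic nitrogen. This is a different kind of change from the measured one: the chain is simply lengthened, propyl to butyl, with no group of the dimethylamino type involved, so the large step between compound 1 and compound 2 bears only loosely on it. In this assay the expected step of a 1.3-fold lower number from compound 2 to compound 3 (0.12 log units; within the scatter) is small, not beyond the scatter. Compound 3 is estimated at 1500 nM, with a range from 500 nM to 4500 nM.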

Compound 3, half-maximal inhibitory concentration: > 50000 nM
Compound 3: a limit, no number (the forecaster's own chance of this, stated with the estimate: 3%); at least 33-fold (1.52 log units) between middle value and limit.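

Lengthening the chain from propyl to butyl, with methyl in place of hydrogen three bonds along the chain from an aromatic nitrogen, proved to be no minor change in this assay: the result is an at least 25-fold higher number from compound 2 to compound 3 (1.40 log units; beyond the scatter). Compound 3 is recorded only as a limit of the assay, and so is compound 1, which leaves compound 2 as the only one of the three with an actual number: the limit of > 50000 nM in this assay, at which 2 of the 3 values shown sit. The earlier compounds shown here tied the loss of a number to the dimethylamino group, whereas this result shows that a plain alkyl chain can reach the same limit, and the step between compound 1 and compound 3 cannot be read, since both are limits.

With a single actual number, the compounds shown give no trend along the chain, so it remains open whether a shorter chain such as ethyl would keep or improve on the value of compound 2. On these data alone, it is also open whether a longer chain such as pentyl, or a hydroxyl or carboxylic acid at the end of the propyl chain, would give a number in this assay.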